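The source may report more compounds than this note shows. Statements on the series, on what has been measured and on what is new or still open speak of the compounds shown alone.

Measured so far:
compound 1, `CCN(C)c1cc(C)nc2c1NC(=O)CN2c1ccc(C(C)C)cc1Br` — 16.4 nM
compound 2, `Cc1cc(N(C)C)c2c(n1)N(c1ccc(C(C)C)cc1Br)CC(=O)N2CCCCF` — 21.6 nM

In an assay on HEK-293T cells for displacement of a labelled ligand from corticotropin-releasing factor receptor 1 (Homo sapiens), read by scintillation counting, with a stated time of 2 h (a higher number here means a weaker inhibitor, a lower number a stronger inhibitor), compound 1 gives 16.4 nM and compound 2 gives 21.6 nM. Compound 2 carries the higher of the two numbers, yet the gap to compound 1 is within the scatter, so the two compounds are read as equivalent in this assay. Among the measured compounds shown here, compound 1 and compound 2 differ from one another in more than one place, so no single step between them can be separated out.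

Compound 3, `CCN(C)c1cc(C)nc2c1N(CCCCF)C(=O)CN2c1ccc(C(C)C)cc1Br`, is not yet measured. It follows from compound 2 by methyl in place of hydrogen on a saturated chain carbon bound to a nitrogen on an aromatic ring; compound 3 thus holds both the ethyl(methyl)amino group of compound 1 and the fluorobutyl chain of compound 2. For the measured compounds named here, nothing among the measured compounds isolates this change, but the two measured values lie close together, and the change adds a single carbon. The expected step from compound 2 to compound 3 in this assay is therefore small, a 1.2-fold lower number from compound 2 to compound 3 (0.08 log units; within the scatter), with no direction beyond the scatter. For compound 3 the estimate in this assay is 18 nM, with a range from 8 nM to 40 nM.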

Compound 3, inhibition constant in the corticotropin-releasing factor receptor 1 assay: 13.9 nM
Compound 3: the middle estimate sits 1.3-fold (0.11 log units) above what was measured, and the stated range covers the measured number.
By their numbers in the corticotropin-releasing factor receptor 1 assay, from the lowest: compounds 3, 1 and 2 (each within the scatter of the next).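

In the corticotropin-releasing factor receptor 1 assay, compound 3 gives 13.9 nM, and the two changes can now be read one at a time: methyl in place of hydrogen on a saturated chain carbon bound to a nitrogen on an aromatic ring gives a step within the scatter (a 1.6-fold lower number from compound 2 to compound 3 (0.19 log units; within the scatter)), and so does 4-fluorobutyl in place of hydrogen on an amide-type nitrogen in a ring (a 1.2-fold lower number from compound 1 to compound 3 (0.07 log units; within the scatter)). With the 4-fluorobutyl chain present, the change from dimethylamino to ethyl(methyl)amino also leaves a physicochemical assay for lipophilicity, at pH 7.4 (on this read-out lower numbers stand for lower lipophilicity and higher numbers for higher lipophilicity), unresolved: compound 2 gives 2.19 and compound 3 gives 2.22, only a step within the scatter (a number 0.03 log units higher from compound 2 to compound 3 (within the scatter)). No measurement offers an explanation for the size of these steps.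

Still open, on these data alone, is whether a longer chain, such as propyl in place of the entering methyl, would also stay within the scatter in the corticotropin-releasing factor receptor 1 assay. The amide-type nitrogen carries only hydrogen or 4-fluorobutyl here, so the contribution of the fluorine remains unresolved, and a plain butyl chain or a chain ending in a hydroxyl group could separate it from that of the chain.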